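The source may report more compounds than this note shows. Statements on the series, on what has been measured and on what is new or still open speak of the compounds shown alone.

Measured so far in an assay on isolated protein for inhibition of serine/threonine-protein kinase TBK1 (Homo sapiens); on this read-out higher numbers stand for weaker inhibition and lower numbers for stronger inhibition:
compound 1 `O=C(NCCCNc1nc(Nc2cccc(F)c2)ncc1Br)c1ccc(C(F)(F)F)cc1`: 450 nM
compound 2 `COCCC(=O)NCCCNc1nc(Nc2cccc(F)c2)ncc1Br`: 60 nM

Compound 2 stands lowest of the two numbers; the nearest is compound 1, reached by a 7.5-fold lower number from compound 1 to compound 2 (0.88 log units; beyond the scatter), a swap of 2-methoxyethyl in place of 4-(trifluoromethyl)phenyl on a carbonyl carbon.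

Compound 3 `CN1CCC(C(=O)NCCCNc2nc(Nc3cccc(F)c3)ncc2Br)CC1` is not yet measured in this assay. It differs from compound 2 by 1-methylpiperidin-4-yl in place of 2-methoxyethyl on a carbonyl carbon; cut one bond further out, (2-methoxyethyl)carbonyl to (1-methylpiperidin-4-yl)carbonyl.

Among the compounds with values here, no measured step covers this exchange. Within the data shown here, the single recorded step, from compound 1 to compound 2, concerns a different pair of groups at that carbonyl carbon and gives no direction for the piperidinyl. With nothing comparable, no step beyond the scatter is expected in this assay. Compound 3 is therefore estimated at 60 nM, within 20 nM to 180 nM. The step this estimate means is expected to be no change at the digits printed from compound 2 to compound 3 (within the scatter).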

Compound 3, half-maximal inhibitory concentration: 4300 nM
Beside the measured number, compound 3's estimate is 72-fold (1.86 log units) below it; measured number above the stated range.
By their numbers in this assay, from the lowest: compound 2; then compound 1; then compound 3.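

At the carbonyl carbon, this assay responds strongly to the group carried: 1-methylpiperidin-4-yl in place of 2-methoxyethyl gives a large step (a 72-fold higher number from compound 2 to compound 3 (1.86 log units; beyond the scatter)). The same group in place of 4-(trifluoromethyl)phenyl also raises the number (a 9.6-fold higher number from compound 1 to compound 3 (0.98 log units; beyond the scatter)), so among these three groups 2-methoxyethyl gives the lowest number and 1-methylpiperidin-4-yl the highest, with 4-(trifluoromethyl)phenyl in the middle, an order the first pair alone could not give. No measurement on hand accounts for these steps.

The compounds shown do not separate the contribution of the six-membered ring from that of its nitrogen and methyl group. Cyclohexyl, tetrahydropyran-4-yl and piperidin-4-yl at the same carbonyl carbon would address this, while a longer chain ending in a dimethylamine would test the nitrogen without the ring.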